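This account rests on a few compounds, and the source may have more. Where it says the series, first, only, none or still open, it means among the compounds named here.

Compound 1 `CC1(C)Cc2c(OCc3ccccc3)ccc(C(=O)/C=C/c3ccc(F)cc3)c2O1` carries a fluoro group on its outer ring, and in a functional assay on NCI-H460 cells (Homo sapiens) for antiproliferative activity, read by MTT assay, with a stated time of 48 h (a lower number here means a stronger inhibitor, a higher number a weaker inhibitor), compound 1 gives 22300 nM. Compound 2 `CC1(C)Cc2c(OCc3ccccc3)ccc(C(=O)/C=C/c3ccc(Br)cc3)c2O1` carries bromo in the same spot. In this assay compound 2 gives only the limit of > 100000 nM. Compound 3 `CC1(C)Cc2c(ccc(C(=O)/C=C/c3ccc(Br)cc3)c2OCc2ccccc2)O1` is built from the same atoms as compound 2 joined differently; the difference between the two cores is not broken down here. In this assay compound 3 also gives only the limit of > 100000 nM. The change from compound 2 to compound 1 is fluoro in place of bromo on an aromatic carbon, and it made an at least 4.4-fold lower number from compound 2 to compound 1 (0.65 log units; beyond the scatter). Compound 4 `CC1(C)Cc2c(ccc(C(=O)/C=C/c3ccc(F)cc3)c2OCc2ccccc2)O1` has not yet been measured. It stands to compound 3 as compound 1 stands to compound 2, by the same change, (fluoro in place of bromo on an aromatic carbon), on the other core. Since two of the three values recorded sit at the limit of > 100000 nM in this assay, at which 2 of the 3 values shown sit, the step on this core can only be read from one side. By analogy with compound 1 and its 22300 nM, compound 4 is expected to give about 30000 nM, somewhere from 10000 nM to 150000 nM. The expected step is an at least 3.3-fold lower number from compound 3 to compound 4 (0.52 log units; beyond the scatter) in this assay.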

Compound 4, half-maximal inhibitory concentration: 75800 nM
The estimate for compound 4 lay 2.5-fold (0.40 log units) below the measured number; the measured number falls inside the stated range.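

In this assay, fluoro in place of bromo on the second core gives an at least 1.3-fold lower number from compound 3 to compound 4 (0.12 log units; that floor lies within the scatter), so this step alone does not show a change beyond the scatter, although it does not contradict the clearer step seen on the first core. From the compounds shown here alone, the change therefore may carry from one core to the other, but its size on the second core stays unknown, and the two steps cannot be compared in size: the same change on two cores in this assay, an at least 4.4-fold lower number (0.65 log units; beyond the scatter) from compound 2 to compound 1 and an at least 1.3-fold lower number (0.12 log units; that floor lies within the scatter) from compound 3 to compound 4; the limit leaves it open whether they differ. Neither bromo compound provides a number from which to measure its step, as each gives only a limit of the assay: the limit of > 100000 nM in this assay, at which 2 of the 4 values shown sit.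

The compounds shown leave open whether chloro, methoxy or a dimethylamino group in place of fluoro on the outer ring would behave alike on both cores. They also leave open whether a free hydroxyl in place of the benzyl ether would alter the values on either core.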